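This account rests on a few compounds, and the source may have more. Where it says the series, first, only, none or still open, it means among the compounds named here.

In a functional assay on brain (Rattus norvegicus, strain Wistar) for inhibition (on this read-out higher numbers stand for weaker inhibition and lower numbers for stronger inhibition), compound 3 `Cc1[nH]c(=O)n(C)c1-c1ccc(CC(C)C)cc1` gives 7800 nM. That value lies within the usual scatter of the two other measured compounds: compound 1 `CCCCc1ccc(-c2c(C)[nH]c(=O)n2C(C)C)cc1` gives 10700 nM and compound 2 `CCCCc1ccc(-c2c(C)[nH]c(=O)n2Cc2ccccc2)cc1` gives 12400 nM. Compound 4 `CCCCCCOc1ccc(-c2c(C)[nH]c(=O)n2C)cc1` has not yet been measured. It carries hexyloxy in place of isobutyl on an aromatic carbon of compound 3 (hexyloxy in place of isobutyl on an aromatic carbon). Within the data shown here, the only measured step, a 1.2-fold higher number from compound 1 to compound 2 (0.06 log units; within the scatter), stayed within the scatter, but it concerns a group on an aromatic nitrogen, so it offers limited guidance on this change. No clear shift is therefore expected in this assay, and the estimated step is a 1.1-fold lower number from compound 3 to compound 4 (0.05 log units; within the scatter). For compound 4 the estimated value is 7000 nM, with an expected range from 2000 nM to 20000 nM.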

Compound 4, half-maximal inhibitory concentration: 7300 nM
For compound 4 the middle estimate is 1.0-fold (0.02 log units) below the measured one, and the stated range covers the measured number.
By their numbers in this assay, from the lowest: compounds 4, 3, 1 and 2 (each within the scatter of the next).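

On the six-membered aromatic ring, hexyloxy in place of isobutyl gives a 1.1-fold lower number from compound 3 to compound 4 (0.03 log units; within the scatter) in this assay. Among these compounds, this is the first look at a change on this ring, as the earlier step concerned a group on an aromatic nitrogen, and it shows that a larger chain carrying an oxygen leaves the number within the scatter. No measurement here offers an explanation for this. Still open, as far as these compounds go, is whether an amine or a carboxylic acid at this position would move the number beyond the scatter.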